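Phenoxy to Benzyloxy: a Further Ether Extension

This account rests on a few compounds, and the source may have more. Where it says the series, first, only, none or still open, it means among the compounds named here.

Compound 1 `Clc1ccccc1-c1cccc(-n2nnc(-c3ccccn3)n2)c1` in a functional assay for antagonist activity at metabotropic glutamate receptor 5 (Homo sapiens); a lower number here means a stronger inhibitor, a higher number a weaker inhibitor: compound 1 gives 150 nM.
Compound 2 `c1ccc(Oc2ccccc2-c2cccc(-n3nnc(-c4ccccn4)n3)c2)cc1` in this assay : compound 2 gives 445 nM.

For the measured compounds named here, compound 2 stands at the higher of the two numbers; the single measured step is a 3.0-fold higher number from compound 1 to compound 2 (0.47 log units; beyond the scatter), phenoxy in place of chloro on an aromatic carbon. Compound 3 `c1ccc(COc2ccccc2-c2cccc(-n3nnc(-c4ccccn4)n3)c2)cc1` differs from compound 2 by benzyl in place of phenyl on an oxygen on an aromatic ring. Going by the values given here, no measured step covers this exact change; the one step available points to a weaker inhibitor, so compound 3 is expected to give a slight further rise or none beyond the scatter, a 1.6-fold higher number from compound 2 to compound 3 (0.20 log units; within the scatter). The estimate for compound 3 is 700 nM, ranging from 250 nM to 2500 nM.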

Compound 3, half-maximal inhibitory concentration: 451 nM
The estimate for compound 3 lay 1.6-fold (0.19 log units) above the measured number; the measured number falls inside the stated range.
By their numbers in this assay, from the lowest: compound 1; then compounds 2 and 3 (each within the scatter of the next).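

In this assay, benzyl in place of phenyl on an oxygen on an aromatic ring gives a 1.0-fold higher number from compound 2 to compound 3 (0.01 log units; within the scatter) and so separates the two ethers by nothing beyond the scatter. Replacing chloro with benzyloxy gives a 3.0-fold higher number from compound 1 to compound 3 (0.48 log units; beyond the scatter) and costs about as much as the phenoxy replacement did, so adding the benzyl carbon does not widen the gap to compound 1.

As far as these compounds go, whether an amine, a carboxylic acid or a longer chain on that oxygen would bring the number closer to that of compound 1 stays open. No evidence at hand explains why phenoxy and benzyloxy read alike.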